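Trimming the Ester to an Acetate in the Anilide Series

The compounds below may be only part of what the source reports. "The series", "measured", "known", "first", "only" and "open" are said of these compounds alone.

Compound 2 `O=C(OC1(C(=O)Nc2ccc([N+](=O)[O-])cc2)CCCCC1)c1ccc([N+](=O)[O-])cc1` stands at the higher end of the two numbers recorded so far: in an ADME assay on WI-38 cells (Homo sapiens) for inhibition, read by MTT assay, with a stated time of 72 h (on this read-out higher numbers stand for weaker inhibition and lower numbers for stronger inhibition), compound 2 gives 761 nM, whereas compound 1 `COc1ccc(C(=O)OC2(C(=O)Nc3ccc([N+](=O)[O-])cc3)CCCCC2)cc1` gives 40 nM in this assay. Going by the values given here, the single measured step, a 19-fold higher number from compound 1 to compound 2 (1.28 log units; beyond the scatter), shows that the group on the ester aryl ring alone can move the read-out substantially.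

Compound 3 `CC(=O)OC1(C(=O)Nc2ccc([N+](=O)[O-])cc2)CCCCC1` has not yet been measured in this assay. Its difference from compound 2 is methyl in place of 4-nitrophenyl on a carbonyl carbon. Among the compounds with values here, no measured step involves this kind of change; the only step on record alters a substituent on that aryl ring rather than removing the ring, so it bears on the new step only loosely. Since the two recorded values bracket a wide span, the estimate for compound 3 is placed between them with broad uncertainty. Compound 3 is expected to give about 350 nM in this assay, with a range from 60 nM to 2000 nM. That corresponds to an expected step of a 2.2-fold lower number from compound 2 to compound 3 (0.34 log units; beyond the scatter), a modest move toward stronger inhibition that may well lie within the scatter.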

Compound 3, half-maximal inhibitory concentration: 386 nM
Compound 3: the middle estimate sits 1.1-fold (0.04 log units) below what was measured; the measured number falls inside the stated range.
By their numbers in this assay, from the lowest: compound 1; then compounds 3 and 2 (each within the scatter of the next).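

The change at this carbonyl carbon removes a whole aromatic ring rather than altering a substituent on it, yet in this assay the replacement of 4-nitrophenyl by methyl gives a 2.0-fold lower number from compound 2 to compound 3 (0.29 log units; within the scatter), so compound 2 and compound 3 cannot be told apart on this read-out. Set against the 4-methoxyphenyl group, the same methyl gives a 9.7-fold higher number from compound 1 to compound 3 (0.98 log units; beyond the scatter), which shows that the stronger inhibition of compound 1 goes with 4-methoxyphenyl on this carbonyl carbon, whereas an aromatic ring as such, present as 4-nitrophenyl in compound 2, does not bring it. Nothing on hand explains why 4-methoxyphenyl stands apart from the other two groups.

As far as these compounds go, it remains open whether the low number of compound 1 needs the methoxy group itself, a question that an unsubstituted phenyl or a ring bearing a dimethylamino group or a hydroxyl could address. From the compounds shown here alone, it is equally open whether a longer chain such as ethyl or butyl, or a carboxylic acid on the chain, would stay level with methyl on this carbonyl carbon or move away from it.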